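The source may report more compounds than this note shows. Statements on the series, on what has been measured and on what is new or still open speak of the compounds shown alone.

Measured so far:

compound 1, `O=C(CCc1ccccc1)n1c(=S)[nH]c2ccccc21`, 100000 nM
compound 2, `O=C(/C=C/c1ccccc1)n1c(=S)oc2ccccc21`, 80000 nM
compound 3, `CCCCCC(=O)n1c(=O)oc2ccccc21`, 150000 nM

In a physicochemical assay for solubility (on this read-out lower numbers stand for lower solubility and higher numbers for higher solubility), compound 1 stands second highest of the three numbers. Its nearest neighbour is compound 2, whose value lies within the scatter of that of compound 1, and its furthest is compound 3, also within the scatter, so the three measured compounds cannot be ordered against each other.

Compound 4, `CCC(=O)n1c(=S)[nH]c2ccccc21`, differs from compound 1 in one place: hydrogen in place of phenyl on a saturated chain carbon, two bonds along the chain from a carbonyl carbon. Going by the values given here, no measured pair shows a change of this kind, so there is no step to rest on. The account expects a moderate rise in this assay from compound 1 to compound 4, somewhat beyond the scatter but not large. The estimated step is a 2.5-fold higher number from compound 1 to compound 4 (0.40 log units; beyond the scatter). Compound 4 is estimated at 250000 nM, with a range from 100000 nM to 600000 nM.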

Compound 4, solubility: 180000 nM
For compound 4 the middle estimate is 1.4-fold (0.14 log units) above the measured one; the range from low to high includes it.
By their numbers in this assay, from the lowest: compounds 2, 1, 3 and 4 (each within the scatter of the next, the first and the last beyond it).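

In this assay, going by these compounds alone, hydrogen in place of phenyl on a saturated chain carbon, two bonds along the chain from a carbonyl carbon, gives a 1.8-fold higher number from compound 1 to compound 4 (0.26 log units; within the scatter), the first comparison here of compounds differing in one place. At this position, then, losing the whole phenyl group leaves the read-out within the scatter. Nothing available accounts for this step.

The compounds shown leave open what an amine, a carboxylic acid or a longer chain would give at this place. Going by these compounds, whether the same change reads alike on another core also stays open.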